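The compounds below may be only part of what the source reports. "The series", "measured", "known", "first", "only" and "open" are said of these compounds alone.

Measured compounds:
Compound 1, `CC[C@@H]1CN(c2scnc2-c2nc3ccccc3[nH]2)CCN1C(=O)Cn1cnc2cccnc21`: 851 nM
Compound 2, `Cc1nc(C)n(CC(=O)N2CCN(c3sc(C(F)(F)F)nc3-c3cnc(OC(C)C)nc3)C[C@H]2C)n1`: 216 nM

Both numbers come from an assay on blood for inhibition of C-X-C chemokine receptor type 3 (Homo sapiens), with a stated time of 30 min; a lower number here means a stronger inhibitor, a higher number a weaker inhibitor. Of the two measured compounds, compound 2 has the lowest number. The nearest measured compound is compound 1, which in this assay gives 851 nM; the gap between compound 1 and compound 2 lies beyond the usual scatter of repeated measurements, so compound 2 is the stronger inhibitor of the two.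

Compound 3, `Cc1nc(C)n(CC(=O)N2CCN(c3sc(C(F)(F)F)nc3-c3ccc(C(F)(F)F)nc3)C[C@H]2C)n1`, has not yet been measured. It differs from compound 2 in one place: 6-(trifluoromethyl)pyridin-3-yl in place of 2-isopropoxypyrimidin-5-yl on an aromatic carbon. Going by the values given here, no pair of measured compounds differs only at this position, so the measurements give no direct step for a change of this kind. On that basis only a small step is expected from compound 2 to compound 3, most likely toward a somewhat higher number, and possibly one that stays within the scatter of this assay.

Compound 3 is therefore estimated at 350 nM in this assay, with an expected range from 120 nM to 1000 nM. This estimate means an expected step of a 1.6-fold higher number from compound 2 to compound 3 (0.21 log units; within the scatter).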

Compound 3, half-maximal inhibitory concentration: 860 nM
For compound 3 the middle estimate is 2.5-fold (0.39 log units) below the measured one; measured number inside the range.
By their numbers in this assay, from the lowest: compound 2; then compounds 1 and 3 (each within the scatter of the next).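

In this assay, going by these compounds alone, putting 6-(trifluoromethyl)pyridin-3-yl in place of 2-isopropoxypyrimidin-5-yl gives a 4.0-fold higher number from compound 2 to compound 3 (0.60 log units; beyond the scatter) and provides the first direct reading at this position: on this aromatic carbon, the two groups are not interchangeable. Both groups have the same count of heavy atoms, so the step cannot be explained by that count alone, although the entering group has one ring hetero atom and one hydrogen-bond acceptor where the leaving group has two ring hetero atoms and three acceptors. Nothing measured here explains the higher number, and the ring and its substituent change together, so the step cannot be assigned to either one.

The compounds shown leave open whether the ring or its substituent accounts for the step, since no compound pairs the pyrimidine ring with trifluoromethyl or the pyridine ring with isopropoxy. From the compounds shown here alone, it also remains open where an unsubstituted pyridin-3-yl group, or a pyridine ring carrying an amine or a methoxy group, would fall relative to compound 2 and compound 3.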